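Swapping cyclohexyl for 4-fluorophenyl in compound 4

This account rests on a few compounds, and the source may have more. Where it says the series, first, only, none or still open, it means among the compounds named here.

Compound 1 `Cc1cc(N2CC[C@@H](C)[C@@H](N(C)c3ncnc4[nH]ccc34)C2)n2nc(SCC3CCCCC3)nc2n1` carries a cyclohexyl group on a saturated chain carbon bound to a sulfur. In a functional assay on BGC-823 cells (Homo sapiens) for inhibition, read by MTT assay, with a stated time of 72 h (on this read-out lower numbers stand for stronger inhibition and higher numbers for weaker inhibition), compound 1 gives 16300 nM, the lowest of the two numbers shown here, with compound 3 nearest. Compound 3 `Cc1ccc(CSc2nc3nc(C)cc(N4CC[C@@H](C)[C@@H](N(C)c5ncnc6[nH]ccc56)C4)n3n2)cc1` gives 69500 nM in this assay, so the step reads a 4.3-fold higher number from compound 1 to compound 3 (0.63 log units; beyond the scatter). Compound 2 `Cc1cc(N2CC[C@@H](C)[C@@H](N(C)c3ncnc4[nH]ccc34)C2)n2nc(SCc3nc4ccccc4[nH]3)nc2n1` reaches only (the limit of > 100000 nM in this assay, at which 1 of the 3 values shown sits). For compound 2 the value > 100000 nM is a limit of this assay and not a number, and the step from compound 1 is accordingly an at least 6.1-fold higher number from compound 1 to compound 2 (0.78 log units; beyond the scatter). Between compound 2 and compound 3 the step is an at least 1.4-fold lower number from compound 2 to compound 3 (0.15 log units; that floor lies within the scatter).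

Compound 4 `Cc1cc(N2CC[C@@H](C)[C@@H](N(C)c3ncnc4[nH]ccc34)C2)n2nc(SCc3ccc(F)cc3)nc2n1` differs from compound 1 in one place: 4-fluorophenyl in place of cyclohexyl on a saturated chain carbon bound to a sulfur. Both earlier exchanges of the cyclohexyl, a 4.3-fold higher number from compound 1 to compound 3 (0.63 log units; beyond the scatter) and an at least 6.1-fold higher number from compound 1 to compound 2 (0.78 log units; beyond the scatter), weakened inhibition, and the 4-methylphenyl case bears most directly on a 4-fluorophenyl. A higher number is therefore expected for compound 4, with a step of about a 3.4-fold higher number from compound 1 to compound 4 (0.53 log units; beyond the scatter). The estimate for compound 4 in this assay is 55000 nM, within 20000 nM to 150000 nM.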

Compound 4, half-maximal inhibitory concentration: 44300 nM
Estimate against measurement, compound 4: 1.2-fold (0.09 log units) above, and the stated range covers the measured number.
By their numbers in this assay, from the lowest: compound 1; then compounds 4 and 3 (each within the scatter of the next). At a limit, above all of these: compound 2.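

With the 4-fluorophenyl, a 2.7-fold higher number from compound 1 to compound 4 (0.43 log units; beyond the scatter) in this assay, so a third replacement of the cyclohexyl on a saturated chain carbon bound to a sulfur also gives a higher number, and compound 1 keeps the lowest number of the four. Fluoro in place of methyl on an aromatic carbon gives a 1.6-fold lower number from compound 3 to compound 4 (0.20 log units; within the scatter), so compound 3 and compound 4 cannot be told apart on this read-out. Compound 2 stands at a limit and not a number, yet the 4-fluorophenyl separates from it, with an at least 2.2-fold lower number from compound 2 to compound 4 (0.35 log units; beyond the scatter), as the 4-methylphenyl did not.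

From the compounds shown here alone, whether a longer chain or a carboxylic acid in place of the cyclohexyl would bring the number below that of compound 1 stays open. Nothing given here accounts for these steps.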